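The compounds below may be only part of what the source reports. "The series", "measured", "known", "first", "only" and "open" are said of these compounds alone.

Compounds measured so far in a functional assay on the whole organism for inhibition, with Mus musculus as the target; on this read-out lower numbers stand for an effect already at smaller amounts and higher numbers for an effect only at larger amounts of compound:
Compound 1 `CCNC(=O)Nc1cccc2c1CN(C)CC2c1ccccc1`: 80 mg/kg
Compound 2 `CCCCNCC(=O)Nc1cccc2c1CN(C)CC2c1ccccc1`: 32 mg/kg

Compound 2, at 32 mg/kg, has the lower of the two numbers. Compound 3 `CCCCNCCC(=O)Nc1cccc2c1CN(C)CC2c1ccccc1` is still unmeasured. It keeps the shared core and changes only the side chain on the carbonyl: (butylamino)methyl in place of butylamino on a saturated chain carbon bound to a carbonyl carbon. Put simply, (butylamino)methyl stands in place of butylamino on a saturated chain carbon bound to a carbonyl carbon.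

Among the compounds with values here, only one measured step bears on this, a 2.5-fold lower number from compound 1 to compound 2 (0.40 log units; beyond the scatter). It is modest, and it is a different change made on the carbonyl carbon itself, so it gives no firm direction. With so little evidence, no clear shift beyond the scatter is expected in this assay. The expected change is a 1.1-fold higher number from compound 2 to compound 3 (0.04 log units; within the scatter). The estimate for compound 3 is 35 mg/kg, with a likely range of 14 mg/kg to 85 mg/kg.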

Compound 3, dose for half-maximal effect: about 46 mg/kg
Beside the measured number, compound 3's estimate is 1.3-fold (0.12 log units) below it, and the stated range covers the measured number.
By their numbers in this assay, from the lowest: compounds 2, 3 and 1 (each within the scatter of the next, the first and the last beyond it).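

In this assay, placing 2-(butylamino)ethyl where compound 2 has (butylamino)methyl gives a 1.4-fold higher number from compound 2 to compound 3 (0.16 log units; within the scatter) at this position on the carbonyl, so the longer chain brings no change that can be told from the usual scatter. Compared with the ethylamino side chain, the step is a 1.7-fold lower number from compound 1 to compound 3 (0.24 log units; within the scatter) and also stays within the scatter, whereas a 2.5-fold lower number from compound 1 to compound 2 (0.40 log units; beyond the scatter) goes beyond it, so compound 3 cannot be clearly separated from either neighbour. No supporting measurement is available to explain these numbers.

From the compounds shown here alone, it remains open whether a still longer chain, such as 3-(butylamino)propyl, would keep the dose in this range. The effect of replacing the butylamino end with a ring amine such as piperidine, or with a carboxylic acid, is also unknown.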